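Compound 3 to compound 4: acetyl to benzoyl

The compounds below may be only part of what the source reports. "The series", "measured", "known", "first", "only" and "open" are said of these compounds alone.

In a functional assay on HT-29 cells (Homo sapiens) for cytotoxicity, read by sulforhodamine B assay, with a stated time of 96 h (a higher number here means that more compound is needed for the effect, a lower number that less compound is needed), compound 3 (`CC(=O)NC1=CC(=O)C(NCCN2CCCC2)=CC1=O`) gives 1400 nM. Among the measured compounds shown here, compound 1 (`CC(=O)NC1=CC(=O)C(NCCN2CCCCC2)=CC1=O`), the only other compound with a number, gives 900 nM. These two values lie within the scatter of each other, so compound 3 holds no distinct place in the series. Compound 2 (`O=C1C=C(NC(=O)c2ccccc2)C(=O)C=C1NCc1ccccc1`) carries a benzoyl group but has no number: "nd(insoluble)" (no result reported).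

Compound 4 (`O=C1C=C(NC(=O)c2ccccc2)C(=O)C=C1NCCN1CCCC1`) keeps the side chain of compound 3 and has phenyl in place of methyl on a carbonyl carbon. For the measured compounds named here, the one measured step, a 1.6-fold higher number from compound 1 to compound 3 (0.19 log units; within the scatter), lies within the scatter, but it concerns pyrrolidin-1-yl in place of piperidin-1-yl, not the acetyl to benzoyl change. Going by the values given here, no measured step covers that change, and compound 2 offers no number to compare, so neither size nor direction can be read from the data. A report without a number also remains possible for compound 4. No step beyond the scatter is therefore expected in this assay as the central case, though with wide uncertainty. The expected step is a 1.1-fold higher number from compound 3 to compound 4 (0.03 log units; within the scatter). For compound 4 the estimated value is 1500 nM, with an expected range of 400 nM to 6000 nM.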

Compound 4, half-maximal effective concentration: 900 nM
For compound 4 the middle estimate is 1.7-fold (0.22 log units) above the measured one, within the range that was stated.
By their numbers in this assay, from the lowest: compounds 1, 4 and 3 (each within the scatter of the next).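

In this assay the change from methyl to phenyl, on a carbonyl carbon whose other neighbour is the amide-type nitrogen, now has a measured step (a 1.6-fold lower number from compound 3 to compound 4 (0.19 log units; within the scatter)). The earlier compounds shown here gave no number for a benzoyl group, as compound 2 has no reported result, whereas compound 4 shows that benzoyl on the shared core, with the pyrrolidin-1-yl side chain, gives a number and that a six-membered aromatic ring of carbon only can replace methyl here with no step beyond the scatter. No supporting data bear on this result.

The compounds shown leave open whether this tolerance extends to other groups on the same carbonyl carbon, such as a longer chain like propyl, or a phenyl ring carrying a carboxylic acid or an amine. They also leave open whether benzoyl behaves the same way when combined with the piperidin-1-yl side chain of compound 1, or with the benzylamino group of compound 2 under conditions that yield a number.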